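The source may report more compounds than this note shows. Statements on the series, on what has been measured and on what is new or still open speak of the compounds shown alone.

Within the data shown here, in a functional assay (plasma) with Oryctolagus cuniculus as the target (a lower number here means a stronger inhibitor, a higher number a weaker inhibitor), compound 2 (`Cc1nc2cnccc2n1CC1CCN(C(=O)CCc2ccccc2)CC1`) gives 60 nM, the higher of the two numbers so far. Among the measured compounds shown here, its only neighbour, compound 1 (`Cc1nc2cnccc2n1CC1CCN(C(=O)CC(C)c2ccccc2)CC1`), gives 12 nM. Compound 3 (`CCOC(=O)C(CC(=O)N1CCC(Cn2c(C)nc3cnccc32)CC1)c1ccccc1`) is not yet measured, and its difference from compound 2 is ethoxycarbonyl in place of hydrogen on a saturated chain carbon bound to an aromatic carbon and a saturated chain carbon.

For the measured compounds named here, one measured step bears on this change, and it sits at the same kind of carbon: a 5.0-fold higher number from compound 1 to compound 2 (0.70 log units; beyond the scatter), with hydrogen in place of methyl. That modest step lies beyond the scatter, and it links a substituent at this carbon with the lower number. Going by the values given here, it is a single pair, however, and no ethoxycarbonyl compound has been measured, so the transfer is uncertain. A modest move towards a lower number is therefore expected in this assay, similar in size to that step or somewhat smaller. The expected step is a 3.0-fold lower number from compound 2 to compound 3 (0.48 log units; beyond the scatter). Compound 3 is estimated at 20 nM, with an expected range of 5 nM to 80 nM.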

Compound 3, half-maximal inhibitory concentration: 12 nM
Compound 3: the middle estimate sits 1.7-fold (0.22 log units) above what was measured, within the range that was stated.
By their numbers in this assay, from the lowest: compounds 1 and 3 (each within the scatter of the next); then compound 2.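

At this saturated chain carbon, ethoxycarbonyl in place of hydrogen gives a 5.0-fold lower number from compound 2 to compound 3 (0.70 log units; beyond the scatter) in this assay, a step that stands beside a 5.0-fold higher number from compound 1 to compound 2 (0.70 log units; beyond the scatter) for the removal of methyl at the same carbon. Ethoxycarbonyl in place of methyl gives no change at the digits printed from compound 1 to compound 3 (within the scatter), so among these compounds both substituents separate from hydrogen in the same direction, and the larger group, with its 5 heavy atoms, brings no loss against methyl. Nothing available here accounts for this shared shift or for the match between the two substituents.

As far as these compounds go, it remains open whether a carboxylic acid, an amine or a longer chain at this carbon would hold the number of compound 1 and compound 3. Also open, from the compounds shown here alone, is whether the ethyl of the ester contributes, which the corresponding methyl ester would test.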